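Removing a trifluoromethyl group from a weak lipoxygenase inhibitor

This account rests on a few compounds, and the source may have more. Where it says the series, first, only, none or still open, it means among the compounds named here.

Two members of a shared core have been measured in an assay on isolated protein for inhibition of Polyunsaturated fatty acid 5-lipoxygenase (Homo sapiens), with stated times of 15 min and 10 min; on this read-out lower numbers stand for stronger inhibition and higher numbers for weaker inhibition. Compound 1 `CC(=O)c1ccc(Nc2nc(-c3ccc(F)cc3)cs2)cc1` gives 4900 nM in this assay. Compound 2 `FC(F)(F)c1ccc(Nc2nc(-c3ccc(Cl)cc3)cs2)cc1` gives 5900 nM in this assay. These two numbers sit within the usual scatter of each other, so neither compound can be set apart from the other on this read-out; both are weak inhibitors.

Compound 3 `Clc1ccc(-c2csc(Nc3ccccc3)n2)cc1` is the untested compound of the set. It differs from compound 2 in one place: hydrogen in place of trifluoromethyl on an aromatic carbon. Among the measured compounds shown here, nothing among the measured pairs shows what this change does in this assay, since no two measured compounds differ in only this one place. With both measured compounds lying close together, the data give no reason to expect a large step. The step from compound 2 to compound 3 is therefore estimated to be small, a modest move toward weaker inhibition that may not exceed the scatter, giving a 1.3-fold higher number from compound 2 to compound 3 (0.10 log units; within the scatter). On that basis compound 3 is expected to give about 7500 nM in this assay, with a range from 2500 nM to 22000 nM.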

Compound 3, half-maximal inhibitory concentration: 5600 nM
Beside the measured number, compound 3's estimate is 1.3-fold (0.13 log units) above it; the range from low to high includes it.
By their numbers in this assay, from the lowest: compounds 1, 3 and 2 (each within the scatter of the next).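

Among the compounds shown here, this is the first single-place step. In this assay, hydrogen in place of trifluoromethyl gives a 1.1-fold lower number from compound 2 to compound 3 (0.02 log units; within the scatter), so on this core and at this position, on an aromatic carbon para to a large group, the trifluoromethyl group can give way to hydrogen without a step that leaves the scatter. The read-out therefore shows no need for trifluoromethyl at this position for inhibition at this weak level, though this rests on a single pair of compounds. No measurement on these compounds bears on why the step is so small, and the result is left without an explanation.

The compounds shown leave open whether any other group at this position, such as an amine, a carboxylic acid or a longer chain, would move the number beyond the scatter in either direction. They also leave open whether hydrogen in place of trifluoromethyl would read the same in a compound carrying fluorine rather than chlorine on the other aromatic ring, as compound 1 does.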